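Replacing methylsulfanyl by a bicyclic amine on the core

The compounds below may be only part of what the source reports. "The series", "measured", "known", "first", "only" and "open" are said of these compounds alone.

Compound 2 `CSc1cc(-c2cnc(N)c(OC(F)F)n2)nc(N2C[C@@H]3C[C@H]2CO3)n1` gives 45 nM in an assay on Sf21 cells for inhibition of mitogen-activated protein kinase kinase kinase 13 (Homo sapiens), read by HTRF, with a stated time of 1.5 h (a higher number here means a weaker inhibitor, a lower number a stronger inhibitor), the lower of the two numbers recorded so far. Compound 1 `Nc1cnc(-c2cc(N3C[C@@H]4C[C@H]3CO4)nc(N3CC4CC3C4)n2)cn1` gives 247 nM in this assay, a higher number, and the gap between compound 1 and compound 2 lies beyond the scatter. Compound 3 `Nc1ncc(-c2cc(N3CC4CC3C4)nc(N3C[C@@H]4C[C@H]3CO4)n2)nc1OC(F)F` is not yet measured. It differs from compound 2 in one place: a group of 6 heavy atoms (5 carbon, 1 nitrogen; one four-membered non-aromatic ring of carbon only, one five-membered non-aromatic ring with 1 hetero atom) in place of a group of 2 heavy atoms (1 carbon, 1 sulfur; no ring), on an aromatic carbon. Within the data shown here, no measured pair shows this exchange on its own; compound 1 carries the entering bicyclic amine but lacks the difluoromethoxy group shared by compound 2 and compound 3, so its number does not isolate the exchange. The change is expected to be small, in either direction, and most likely within the scatter, with a modest gain judged slightly more likely than a loss. Compound 3 is expected at 30 nM in this assay, with a range from 8 nM to 120 nM. This estimate means a step of a 1.5-fold lower number from compound 2 to compound 3 (0.18 log units; within the scatter), expected to remain within the scatter.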

Compound 3, half-maximal inhibitory concentration: 35 nM
Compound 3: the middle estimate sits 1.2-fold (0.07 log units) below what was measured; the measured number falls inside the stated range.
By their numbers in this assay, from the lowest: compounds 3 and 2 (each within the scatter of the next); then compound 1.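

In this assay, among these compounds, the exchange of methylsulfanyl for the bicyclic amine gives a 1.3-fold lower number from compound 2 to compound 3 (0.11 log units; within the scatter), the first pair of compounds to isolate this change. This position, on an aromatic carbon next to the ring nitrogen, therefore accepts a group of 6 heavy atoms with two rings in place of a group of 2 heavy atoms with no ring, and the two groups cannot be told apart by this read-out. No measurement at hand accounts for this lack of separation.

Going by these compounds, whether the position stays as accommodating with other groups, such as morpholine, a methoxy group or a longer carbon chain, remains open. This single pair also leaves open whether the same exchange would read alike on a core without the difluoromethoxy group.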